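This account rests on a few compounds, and the source may have more. Where it says the series, first, only, none or still open, it means among the compounds named here.

Compound 3 `Cc1cc(=O)n(-c2ccc(Br)cc2F)nc1C(=O)Nc1ccc(Oc2ncnc3ccsc23)c(F)c1` gives the lowest number of the three measured compounds in a functional assay on A549 cells (Homo sapiens) for cytotoxicity, read by MTT assay, with a stated time of 72 h (on this read-out lower numbers stand for stronger inhibition and higher numbers for weaker inhibition), at 2980 nM. Compound 2 `Cc1cc(=O)n(-c2ccccc2C(F)(F)F)nc1C(=O)Nc1ccc(Oc2ncnc3ccsc23)c(F)c1` gives 4680 nM, and compound 1 `CNC(=O)c1cc(Oc2ccc(NC(=O)c3nn(-c4ccc(Br)cc4F)c(=O)cc3C)cc2F)ccn1` gives 7930 nM. Compound 4 `Cc1ccc(-n2nc(C(=O)Nc3ccc(Oc4ncnc5ccsc45)c(F)c3)c(C)cc2=O)cc1` differs from compound 3 by 4-methylphenyl in place of 4-bromo-2-fluorophenyl on an aromatic nitrogen. The step that bears on this is the one at the same aromatic nitrogen, a 1.6-fold lower number from compound 2 to compound 3 (0.20 log units; within the scatter), which stayed within the scatter; the step of a 2.7-fold lower number from compound 1 to compound 3 (0.43 log units; beyond the scatter) concerns a different part of the molecule. A change of only the group on that nitrogen is therefore expected to move the number little, so compound 4 is estimated at 3800 nM with a range from 1500 nM to 9000 nM, an expected step of a 1.3-fold higher number from compound 3 to compound 4 (0.11 log units; within the scatter).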

Compound 4, half-maximal inhibitory concentration: 5890 nM
Compound 4: the middle estimate sits 1.6-fold (0.19 log units) below what was measured, within the range that was stated.
By their numbers in this assay, from the lowest: compounds 3, 2, 4 and 1 (each within the scatter of the next, the first and the last beyond it).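

In this assay, both steps to the 4-methylphenyl compound stay within the scatter: a 2.0-fold higher number from compound 3 to compound 4 (0.30 log units; within the scatter) and a 1.3-fold higher number from compound 2 to compound 4 (0.10 log units; within the scatter). Compounds 2, 3 and 4 therefore cannot be told apart by this change on the aromatic nitrogen, even though the group in compound 4 carries neither fluorine nor bromine. Nothing on hand explains this result.

From the compounds shown here alone, whether this position tolerates any group on the phenyl ring remains open. A carboxylic acid or an amine there could still move the number well beyond the scatter.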